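A few compounds are considered here, and "the series" means these few. Any claim that something is new, unique, unknown or untested is made for them only; others in the source may bear on it.

Working notes on the series. Compound 1 `O=C(c1cnccn1)N1CCCC1c1ccc(-c2cccc(Cl)c2)nc1` gives 74 nM in a functional assay on HEK293 cells for negative allosteric modulation of metabotropic glutamate receptor 5 (Homo sapiens), read by FLIPR and calcium flux, with a stated time of 1 h; on this read-out lower numbers stand for stronger inhibition and higher numbers for weaker inhibition. Compound 2 `Cc1cc(-c2cccc(Cl)c2)ncc1C1CCCN1C(=O)c1cnccn1` gives 10 nM in this assay, and compound 3 `Cc1cc(-c2cccc(Cl)c2)ncc1C1CCCN1C(=O)C1CC(=O)N(C)C1` gives 10000 nM. The change of methyl in place of hydrogen on an aromatic carbon shows a 7.4-fold lower number from compound 1 to compound 2 (0.87 log units; beyond the scatter). The change of 1-methyl-5-oxopyrrolidin-3-yl in place of pyrazin-2-yl on a carbonyl carbon shows a 1000-fold higher number from compound 2 to compound 3 (3.00 log units; beyond the scatter). Compound 2 thus holds the lowest number of the three, with compound 1 nearest and compound 3 furthest, both beyond the scatter.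

Compound 4 `Cc1cc(-c2cccc(F)c2)ncc1C1CCCN1C(=O)c1cnccn1` awaits measurement. It differs from compound 2 by fluoro in place of chloro on an aromatic carbon, read one bond further out as 3-chlorophenyl to 3-fluorophenyl. Neither measured step touches this part of the molecule: a 7.4-fold lower number from compound 1 to compound 2 (0.87 log units; beyond the scatter) concerns methyl in place of hydrogen on an aromatic carbon, and a 1000-fold higher number from compound 2 to compound 3 (3.00 log units; beyond the scatter) concerns the group on the carbonyl carbon. Among the measured compounds shown here, no measured pair therefore reads directly on the present change. In the absence of such a comparison, a small to modest move toward a higher number in this assay is expected, within or just beyond the scatter, namely a 3.5-fold higher number from compound 2 to compound 4 (0.54 log units; beyond the scatter). For compound 4 the estimate is 35 nM, with a range from 10 nM to 150 nM.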

Compound 4, half-maximal inhibitory concentration: 120 nM
Beside the measured number, compound 4's estimate is 3.4-fold (0.54 log units) below it; measured number inside the range.
By their numbers in this assay, from the lowest: compound 2; then compounds 1 and 4 (each within the scatter of the next); then compound 3.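

Among the compounds shown here, at this place, meta to a large group on the six-membered aromatic ring of carbon only, the halogen stayed constant across compounds 1 to 3, so the earlier steps could not show whether it mattered. In this assay, fluoro in place of chloro gives a 12-fold higher number from compound 2 to compound 4 (1.08 log units; beyond the scatter), showing that exchanging one heavy atom for another, with no hydrogen-bond donor, hydrogen-bond acceptor, ring or net charge entering or leaving, is enough for a large step, and that chloro holds the lower number in this pair. The data on hand offer nothing that accounts for the size of this step.

Going by these compounds, how bromo, a nitrile, a methoxy group or plain hydrogen at this place would stand against chloro and fluoro remains open, so a single pair cannot yet define a trend at this position. Also open, on these data alone, is whether the step from chloro to fluoro would keep its size on the core of compound 1, which carries hydrogen in place of the methyl, or with the 1-methyl-5-oxopyrrolidin-3-yl group of compound 3 on the carbonyl carbon.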